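Dropping One Methoxy Group from Compound 3

The source may hold more compounds than are shown below. What is called first, only, known or untested is meant among the compounds shown, and "the series" means these compounds.

Measured so far in an ADME assay on RAW264.7 cells (Mus musculus) for cytotoxicity, read by MTT assay, with a stated time of 24 h, tested at 5 ug/mL; a lower number here means a stronger effect, a higher number a weaker effect of the compound at the concentration tested:
compound 1, `COc1ccc(/C=C/C(=O)c2ccc(OC)c(OC)c2)cc1`, gives 78.9%
compound 2, `COc1ccc(/C=C/C(=O)c2ccc(OC)c(OC)c2)cc1OC`, gives 81.3%
compound 3, `COc1ccc(CCCc2ccc(OC)c(OC)c2OC)c(O)c1`, gives 84.5%

Compound 2 and compound 1 differ in one place, (hydrogen in place of methoxy on an aromatic carbon), and the step is a number 2.4 percentage points lower from compound 2 to compound 1 (within the scatter). How the core of compound 3 differs from that of compound 2 is not broken down here; their two values lie within the scatter of each other.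

Compound 4, `COc1ccc(CCCc2cccc(OC)c2OC)c(O)c1`, has not yet been measured. It differs from compound 3 by hydrogen in place of methoxy on an aromatic carbon. This is the same kind of change as that from compound 2 to compound 1, but the surroundings differ: in compound 3 the place is also meta to a methoxy group and para to a large group, whereas in compound 2 it is meta to a large group.

Because the earlier step of a number 2.4 percentage points lower from compound 2 to compound 1 (within the scatter) stayed within the scatter, the expected step is a number 2.5 percentage points lower from compound 3 to compound 4 (within the scatter). Compound 4 is therefore estimated at 82%, expected to lie between 72% and 92%.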

Compound 4, a percentage reported as activity, at one concentration (the size of the read-out at that concentration, not a potency): 95.2%
Beside the measured number, compound 4's estimate is 13.2 percentage points below it; measured number above the stated range.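

On the core of compound 3, swapping the methoxy group for hydrogen gives a number 10.7 percentage points higher from compound 3 to compound 4 (beyond the scatter) in this assay, meaning a weaker effect at the concentration tested. Set beside the earlier case, this larger step still cannot be told apart from it: the same change on two cores in this assay, a number 2.4 percentage points lower (within the scatter) from compound 2 to compound 1 and a number 10.7 percentage points higher (beyond the scatter) from compound 3 to compound 4, 13.1 percentage points apart, within the scatter of two such steps The two pairs therefore do not show that the change behaves differently on the two cores, nor do they prove that it carries over unchanged.

The compounds shown leave open how an amine or a carboxylic acid at the same place would read in this assay. They also give no potency, as each value comes from a single concentration.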